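Swapping the tetrazole tail for a methylsulfonyl group

This account rests on a few compounds, and the source may have more. Where it says the series, first, only, none or still open, it means among the compounds named here.

Compound 3 `CCc1cc(C(C)=O)c(O)cc1OCCCCCCC(C)(C)c1nnn[nH]1` gives 67% in an assay on isolated protein for binding affinity to leukotriene B4 receptor 1 (Homo sapiens), tested at 1 uM (a higher number here means more inhibition at the concentration tested (going by the name of the read-out), a lower number less inhibition), the highest of the three numbers measured; compound 2 `CCc1cc(C(C)=O)c(O)cc1OCCCCCC(C)(C)C#N` gives 53% and compound 1 `CCc1cc(C(C)=O)c(O)cc1OCCCCC(C)(C)C#N` gives 30%. Compound 4 `CCc1cc(C(C)=O)c(O)cc1OCCCCCCS(C)(=O)=O` has not been measured. It differs from compound 3 in one place (methylsulfonyl in place of 1-(1H-tetrazol-5-yl)-1-methylethyl on a saturated chain carbon, six bonds along the chain from an oxygen on an aromatic ring).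

Within the data shown here, two steps bear on this, both loosely. The step of a number 23 percentage points higher from compound 1 to compound 2 (beyond the scatter) lengthened the chain by one carbon. The step of a number 14 percentage points higher from compound 2 to compound 3 (beyond the scatter) lengthened it again and brought the tetrazole in place of the nitrile. Among the measured compounds shown here, no measured pair shows a methylsulfonyl group, and none shows the tetrazole leaving. For the measured compounds named here, since the only step that introduced the tetrazole rose, its departure for a smaller group is expected to cost some inhibition, so a downward step a number 27 percentage points lower from compound 3 to compound 4 (beyond the scatter) is expected, with wide uncertainty.

Compound 4 is therefore estimated at 40%, within a range from 15% to 65%.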

Compound 4, a percentage reported as inhibition, at one concentration (the size of the read-out at that concentration, not a potency): 62%
Compound 4: the middle estimate sits 22 percentage points below what was measured, and the stated range covers the measured number.
By their numbers in this assay, from the lowest: compound 1; then compounds 2, 4 and 3 (each within the scatter of the next, the first and the last beyond it).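

In this assay the 1-(1H-tetrazol-5-yl)-1-methylethyl group at this place on the chain can give way to methylsulfonyl, which has no ring and no hydrogen-bond donor, with a number 5 percentage points lower from compound 3 to compound 4 (within the scatter) so neither the ring nor its donor is required for this level of inhibition. Among these compounds, measured against the nitrile on the next shorter chain, the change gives a number 9 percentage points higher from compound 2 to compound 4 (within the scatter) and against the nitrile on the shortest chain it gives a number 32 percentage points higher from compound 1 to compound 4 (beyond the scatter) and only this last step of the three lies beyond the scatter. Nothing available explains why groups this different give such close numbers.

The compounds shown leave open how methylsulfonyl behaves on a shorter or a longer chain. They also leave open whether a carboxylic acid or an amine at this place would give a number close to those of compound 3 and compound 4.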